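A few compounds are considered here, and "the series" means these few. Any claim that something is new, unique, unknown or untested is made for them only; others in the source may bear on it.

In a functional assay on MCF7 cells (Homo sapiens) for antiproliferative activity, read by MTT assay, with a stated time of 72 h (a lower number here means a stronger inhibitor, a higher number a weaker inhibitor), three compounds have been measured:

- Compound 1 `CC/C=C/C(=O)Nc1cccc(Oc2nc(Nc3ccn(C)n3)nc3c2CSCC3)c1`: > 50000 nM (a limit of the assay)
- Compound 2 `CC/C=C/C(=O)Nc1cccc(Oc2nc(Nc3ccc(OC)cc3)nc3c2CSCC3)c1`: 31400 nM
- Compound 3 `C/C=C/C(=O)Nc1cccc(Oc2nc(Nc3ccc(OC)nc3)nc3c2CSCC3)c1`: 21100 nM

Compound 1 is reported only as a limit, > 50000 nM. Compound 3, at 21100 nM, lies within the scatter of compound 2, at 31400 nM, so this assay does not separate the two.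

Compound 4 `CC/C=C/C(=O)Nc1cccc(Oc2nc(Nc3ccc(OC)nc3)nc3c2CSCC3)c1` differs from compound 3 in one place: methyl in place of hydrogen on a saturated chain carbon bound to a double-bonded chain carbon. Cut one bond further out, the same difference reads prop-1-en-1-yl to but-1-en-1-yl.

Among the compounds with values here, the only measured step, an at least 1.5-fold lower number from compound 1 to compound 2 (0.20 log units; that floor lies within the scatter), exchanges 1-methyl-1H-pyrazol-3-yl for 4-methoxyphenyl on a nitrogen on an aromatic ring. Within the data shown here, that is a different place, so it gives no direct measure of this change, and no measured step covers it. Compound 2 already carries but-1-en-1-yl and gives 31400 nM, although it also differs from compound 3 in its other group. With this in view, no shift beyond the scatter is expected in this assay. The expected change is a 1.1-fold higher number from compound 3 to compound 4 (0.04 log units; within the scatter).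

Compound 4 is estimated at 23000 nM, with an expected range from 11000 nM to 45000 nM.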

Compound 4, half-maximal inhibitory concentration: 31500 nM
Compound 4: middle estimate off by 1.4-fold (0.14 log units), on the low side; measured number inside the range.
By their numbers in this assay, from the lowest: compounds 3, 2 and 4 (each within the scatter of the next). At a limit, above all of these: compound 1.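

In this assay, going from prop-1-en-1-yl to but-1-en-1-yl, with methyl in place of hydrogen on a saturated chain carbon bound to a double-bonded chain carbon, gives a 1.5-fold higher number from compound 3 to compound 4 (0.17 log units; within the scatter), so the first direct measure of this change shows a step that this assay does not resolve. Within the data shown here, with but-1-en-1-yl held the same, 6-methoxypyridin-3-yl in place of 4-methoxyphenyl on a nitrogen on an aromatic ring gives a 1.0-fold higher number from compound 2 to compound 4 (0.00 log units; within the scatter), which isolates that exchange in one place for the first time and shows that it is not resolved either. The exchange of 1-methyl-1H-pyrazol-3-yl for 6-methoxypyridin-3-yl gives an at least 1.5-fold lower number from compound 1 to compound 4 (0.20 log units; that floor lies within the scatter), which is only a floor, since the value for compound 1 is a limit of the assay: the limit of > 50000 nM in this assay, at which 1 of the 4 values shown sits.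

The compounds shown leave open whether a longer chain such as pent-1-en-1-yl, or a ring such as phenyl, at this place would move the number beyond the scatter. They also leave open how large the step from 1-methyl-1H-pyrazol-3-yl really is.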